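The source may report more compounds than this note shows. Statements on the series, on what has been measured and on what is new or still open speak of the compounds shown alone.

Measured so far in a functional assay on the whole organism (blood, strain Wistar-Okamoto) with Rattus norvegicus as the target, with a stated time of 5 days; on this read-out higher numbers stand for an effect only at larger amounts of compound and lower numbers for an effect already at smaller amounts:
compound 1 `CCC/N=C(\NC#N)Nc1cccnc1` gives 20 mg/kg
compound 2 `CCC(C)(CC)/N=C(\NC#N)Nc1cccnc1` gives 0.5 mg/kg

Compound 1 has the highest number of the two; its nearest neighbour is compound 2, reached by a 40-fold lower number from compound 1 to compound 2 (1.60 log units; beyond the scatter). Compound 3 `N#CN/C(=N\Cc1ccccc1)Nc1cccnc1` differs from compound 1 by one change: phenyl in place of ethyl on a saturated chain carbon bound to a double-bonded nitrogen. Within the data shown here, the only measured step at this place is the one to compound 2, where a larger group on the double-bonded nitrogen brought a large drop in the number, so a drop is also expected from compound 1 to compound 3, though a smaller one, because a 40-fold lower number from compound 1 to compound 2 (1.60 log units; beyond the scatter) came from a different group. Compound 3 is therefore expected to give about 5 mg/kg, between 1 mg/kg and 20 mg/kg. The expected step is a 4.0-fold lower number from compound 1 to compound 3 (0.60 log units; beyond the scatter).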

Compound 3, minimum effective dose: 20 mg/kg
Compound 3: the middle estimate sits 4.0-fold (0.60 log units) below what was measured; low and high end bracket the measured number.
By their numbers in this assay, from the lowest: compound 2; then compounds 1 and 3 (each within the scatter of the next).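

With phenyl in place of ethyl on a saturated chain carbon bound to a double-bonded nitrogen, the result is no change at the digits printed from compound 1 to compound 3 (within the scatter), so more heavy atoms at this place do not by themselves lower the number. The earlier step, a 40-fold lower number from compound 1 to compound 2 (1.60 log units; beyond the scatter), therefore does not extend to every bulkier replacement of the propyl group. Nothing available here explains this difference between the two changes. Going by these compounds, it remains open whether a tert-butyl group or a longer unbranched chain on the double-bonded nitrogen would lower the number.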